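The source may hold more compounds than are shown below. What is called first, only, known or untested is meant among the compounds shown, and "the series" means these compounds.

In a functional assay on A549 cells (Homo sapiens), read by MTT assay, with a stated time of 72 h (on this read-out higher numbers stand for weaker inhibition and lower numbers for stronger inhibition), compound 1 `C#Cc1cn([C@@H]2O[C@H](CO)[C@@H](O)[C@H]2O)c2ncnc(OC)c12` gives 8160 nM and compound 2 `CSc1ncnc2c1c(-c1ccoc1)cn2[C@@H]1O[C@H](CO)[C@@H](O)[C@H]1O` gives 280 nM. Compound 2 holds the lower of the two numbers, and the gap lies beyond the usual scatter. Compound 3 `CSc1ncnc2c1c(-c1cccs1)cn2[C@@H]1O[C@H](CO)[C@@H](O)[C@H]1O` is not yet measured. Its change from compound 2 is thiophen-2-yl in place of furan-3-yl on an aromatic carbon. Among the measured compounds shown here, no measured pair isolates a change at this place. Both groups are five-membered aromatic rings with 1 hetero atom, and no change beyond the scatter is expected, in either direction. The expected step is a 1.1-fold lower number from compound 2 to compound 3 (0.05 log units; within the scatter). The estimated value for compound 3 is 250 nM, with a range of 80 nM to 800 nM.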

Compound 3, half-maximal inhibitory concentration: > 20000 nM
Compound 3: only a limit was reported; the forecaster's own chance of this, stated with the estimate: 5%; at least 80-fold (1.90 log units) between middle value and limit.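

In this assay, this aromatic carbon does not treat two five-membered aromatic rings with 1 hetero atom alike: thiophen-2-yl in place of furan-3-yl gives an at least 71-fold higher number from compound 2 to compound 3 (1.85 log units; beyond the scatter), with heavy-atom, donor and acceptor counts unchanged. Among the compounds shown here, no earlier pair showed this sensitivity at the position. Compound 3 carries a limit of the assay, not a number: the limit of > 20000 nM in this assay, at which 1 of the 3 values shown sits.

The change alters both the hetero atom and the ring atom of attachment, and the compounds shown do not separate the two; furan-2-yl or thiophen-3-yl would bear on this. Going by these compounds, how an aminomethyl or a carboxylic acid on the furan ring would read also remains open.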